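Amide series: piperidinyl to diisopropyl amide

The source may report more compounds than this note shows. Statements on the series, on what has been measured and on what is new or still open speak of the compounds shown alone.

Measured so far:
compound 1, `CS(=O)(=O)c1ccc(C(=O)NCCC(=O)N2CCCCC2)cc1[N+](=O)[O-]` — > 27000 nM in an ADME assay on HepG2 cells (Homo sapiens) for cytotoxicity, read by CellTiter-Glo and ATP content, with a stated time of 72 h; on this read-out lower numbers stand for an effect already at smaller amounts and higher numbers for an effect only at larger amounts of compound (a limit of the assay, not a number)
compound 2, `CS(=O)(=O)c1ccc(C(=O)N2CCC(C(=O)N3CCC(c4ccccc4)CC3)CC2)cc1[N+](=O)[O-]` — > 27000 nM (likewise a limit)

Compound 1 sits only at a limit in this assay, so no number places it. Going by the values given here, the same holds for compound 2, and the limit of > 27000 nM in this assay, at which 2 of the 2 values shown sit, covers both values shown; no step between measured compounds can be read from them.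

Compound 3, `CC(C)N(C(=O)CCNC(=O)c1ccc(S(C)(=O)=O)c([N+](=O)[O-])c1)C(C)C`, carries diisopropylamino in place of piperidin-1-yl on a carbonyl carbon whose other neighbour is a saturated chain carbon, the change reading, one bond further out, as (piperidin-1-yl)carbonyl to diisopropylcarbamoyl.

With both measured values at the limit, no step size can be drawn from the numbers; for compound 3 a step that the limit leaves unreadable from compound 1 to compound 3 is expected, that is, none beyond the scatter, and it is expected to be reported again as a limit rather than a number. The estimate for compound 3 is 30000 nM, within 15000 nM to 80000 nM.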

Compound 3, half-maximal effective concentration: > 27000 nM
Compound 3 gave a limit, no number; the forecaster's own chance of this, stated with the estimate: 85%; the middle value does not contradict the limit.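

No step can be read from compound 1 to compound 3, as each gives a limit of the assay and not a number: the limit of > 27000 nM in this assay, at which 3 of the 3 values shown sit.

The compounds shown leave open whether diisopropylamino in place of piperidin-1-yl on a carbonyl carbon shifts the read-out at all in this assay.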